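A Five-Membered Oxygen Ring Replaces the Phenyl Ring

The source may hold more compounds than are shown below. What is called first, only, known or untested is meant among the compounds shown, and "the series" means these compounds.

Compound 1 `NCc1ccccc1CN(Cc1nc2ccccc2[nH]1)C1CCCc2cccnc21` gives 28 nM in a functional assay on CEM-CCRF cells for antagonist activity at C-X-C chemokine receptor type 4 (Homo sapiens), read by calcium flux; a lower number here means a stronger inhibitor, a higher number a weaker inhibitor.
Compound 2 `NCc1ccc(CN(Cc2nc3ccccc3[nH]2)C2CCCc3cccnc32)c(CN)c1` gives 10 nM in this assay.
Compound 3 `NCc1sccc1CN(Cc1nc2ccccc2[nH]1)C1CCCc2cccnc21` gives 60 nM in this assay.

Among these three numbers, compound 1 stands second highest. Its nearer neighbour is reached by a 2.1-fold higher number from compound 1 to compound 3 (0.33 log units; beyond the scatter), its further neighbour by a 2.8-fold lower number from compound 1 to compound 2 (0.45 log units; beyond the scatter).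

Compound 4 `NCc1ccoc1CN(Cc1nc2ccccc2[nH]1)C1CCCc2cccnc21` has not yet been measured in this assay. It differs from compound 1 in one place: a group of 7 heavy atoms (5 carbon, 1 nitrogen, 1 oxygen; one five-membered aromatic ring with 1 hetero atom) in place of a group of 8 heavy atoms (7 carbon, 1 nitrogen; one six-membered aromatic ring of carbon only), on a saturated chain carbon bound to an amine nitrogen. Going by the values given here, the measured step that bears most on this is the one to compound 3, where a five-membered ring with a sulfur atom entered at the same place and the number rose modestly, a 2.1-fold higher number from compound 1 to compound 3 (0.33 log units; beyond the scatter). The step to compound 2, a 2.8-fold lower number from compound 1 to compound 2 (0.45 log units; beyond the scatter), concerns a different change and says little here. Resting on this single comparison, a modest rise of similar size is expected for compound 4, a 2.0-fold higher number from compound 1 to compound 4 (0.29 log units; within the scatter). Compound 4 is therefore estimated at 55 nM, with a range from 25 nM to 120 nM.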

Compound 4, half-maximal inhibitory concentration: 12 nM
Beside the measured number, compound 4's estimate is 4.6-fold (0.66 log units) above it; the whole stated range lies above it.
By their numbers in this assay, from the lowest: compounds 2 and 4 (each within the scatter of the next); then compound 1; then compound 3.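

In this assay, replacing the 2-(aminomethyl)phenyl group with the five-membered oxygen ring gives a lower number (a 2.3-fold lower number from compound 1 to compound 4 (0.37 log units; beyond the scatter)), so at this place a five-membered aromatic ring need not cost activity, as the sulfur ring alone had suggested. The hetero atom in the ring matters, since exchanging sulfur for oxygen gives a clear drop (a 5.0-fold lower number from compound 3 to compound 4 (0.70 log units; beyond the scatter)). The second aminomethyl group on the phenyl ring is also not needed to reach a number of this size (a 1.2-fold higher number from compound 2 to compound 4 (0.08 log units; within the scatter)).

Nothing given here explains why the oxygen and sulfur rings differ. Going by these compounds, it remains open whether a pyrrole ring, with nitrogen as its hetero atom, or a longer aminoethyl chain in place of aminomethyl on the oxygen ring would keep the number this low.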